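Fluorine on the anilide ring of a growth inhibitor

This account rests on a few compounds, and the source may have more. Where it says the series, first, only, none or still open, it means among the compounds named here.

Measured compounds in a functional assay on MCF7 cells (Homo sapiens) for inhibition, read by MTT assay; a lower number here means a stronger inhibitor of growth, a higher number a weaker inhibitor of growth:
compound 1 `CC1=C(/C=C/C(C)=C/C=C/C(C)=C\C(=O)Nc2ccccc2)C(C)(C)CC=C1c1cccnc1` gives 8320 nM
compound 2 `CC1=C(/C=C/C(C)=C/C=C/C(C)=C\C(=O)Nc2ccccc2)C(C)(C)CCC1n1ccnc1` gives 1900 nM
compound 3 `CC1=C(/C=C/C(C)=C/C=C/C(C)=C\C(=O)Nc2ccccc2)C(C)(C)CC=C1c1cncnc1` gives 7010 nM

Among these three, compound 2 gives the lowest number in this assay, and its gaps to compound 3 and to compound 1 both lie beyond the scatter, so it is the strongest inhibitor of growth shown here. Compounds 1 and 3 differ from each other only at the double-bonded ring carbon, and that change, a 1.2-fold lower number from compound 1 to compound 3 (0.07 log units; within the scatter), is within the scatter.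

Compound 4 `CC1=C(/C=C/C(C)=C/C=C/C(C)=C\C(=O)Nc2cccc(F)c2)C(C)(C)CCC1n1ccnc1` is built from compound 2 by a single change: fluoro in place of hydrogen on an aromatic carbon. Cut one bond further out, this reads phenyl to 3-fluorophenyl, or phenylcarbamoyl to (3-fluorophenyl)carbamoyl.

Among the compounds with values here, none of the measured steps touches this part of the molecule: the only step available compares two heteroaryl groups on the other end of the shared core, and it was within the scatter. Within the data shown here, there is thus no measured precedent for a fluoro in place of hydrogen on the anilide ring, and a single fluorine is a small addition. Compound 4 is therefore expected to stay close to compound 2, with a step of no change at the digits printed from compound 2 to compound 4 (within the scatter) that lies within the scatter. The estimate for compound 4 in this assay is 1900 nM, with a range from 800 nM to 4500 nM.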

Compound 4, concentration for 50% growth inhibition: 5490 nM
Compound 4: middle estimate off by 2.9-fold (0.46 log units), on the low side; measured number above the stated range.
By their numbers in this assay, from the lowest: compound 2; then compounds 4, 3 and 1 (each within the scatter of the next).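

In this assay the anilide ring proves not to be a silent position: 3-fluorophenyl in place of phenyl gives a 2.9-fold higher number from compound 2 to compound 4 (0.46 log units; beyond the scatter) and so makes compound 4 a weaker inhibitor of growth, even though only a single fluorine atom enters, on an aromatic carbon meta to a large group. The one earlier step, between two heteroaryl groups at the other end of the shared core, stayed within the scatter, so this is the only change shown on the anilide ring and the only single-place step shown that lies beyond the scatter. No measurement accompanying these compounds bears on why the number rises.

With one substituent at one place, the compounds shown leave open whether this step is particular to fluoro or would also appear with chloro, methoxy or hydroxyl on the same carbon. They also leave open whether fluoro on other carbons of the anilide ring would give a step of similar size, and whether the same change would carry over to compound 1 with its pyridin-3-yl group.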